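Chloro for methyl on the shared core: expected growth inhibition

The compounds below may be only part of what the source reports. "The series", "measured", "known", "first", "only" and "open" are said of these compounds alone.

The series shares a core and differs only in the substituents on its aromatic part. Compound 3 `COC(=O)[C@@]1(C)CCC=C2[C@@H]1CC[C@@H](C)[C@]2(C)Cc1c(C)[nH]c2c(C)cccc12` gives 19000 nM in a functional assay on T47D cells (Homo sapiens) for inhibition, read by sulforhodamine B assay, with a stated time of 48 h (on this read-out lower numbers stand for stronger inhibition of growth and higher numbers for weaker inhibition of growth), the second highest of the three numbers. Its nearest neighbour is compound 2 `COC(=O)[C@@]1(C)CCC=C2[C@@H]1CC[C@@H](C)[C@]2(C)Cc1c(C)[nH]c2ccccc12`, which gives 17000 nM in this assay; the furthest is compound 1 `COC(=O)[C@@]1(C)CCC=C2[C@@H]1CC[C@@H](C)[C@]2(C)Cc1c[nH]c2c(Cl)cccc12`, which gives 24000 nM, and both gaps fall within the scatter. Compound 4 `COC(=O)[C@@]1(C)CCC=C2[C@@H]1CC[C@@H](C)[C@]2(C)Cc1c(C)[nH]c2c(Cl)cccc12` has not yet been measured. It differs from compound 3 by chloro in place of methyl on an aromatic carbon. Among the compounds with values here, the only single step measured so far is a 1.1-fold higher number from compound 2 to compound 3 (0.05 log units; within the scatter), which shows that adding a methyl there changes little. Within the data shown here, no measured step swaps chloro for methyl; compound 1 carries the chloro without the second methyl and sits within the scatter of both compounds 2 and 3. Because the step of a 1.1-fold higher number from compound 2 to compound 3 (0.05 log units; within the scatter) and the values of compound 1 and compound 3 all lie within the scatter, compound 4 is expected to show a step of a 1.1-fold higher number from compound 3 to compound 4 (0.04 log units; within the scatter), no change beyond the scatter. The estimate for compound 4 is therefore 21000 nM, with a range from 10000 nM to 45000 nM.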

Compound 4, concentration for 50% growth inhibition: 27000 nM
For compound 4 the middle estimate is 1.3-fold (0.11 log units) below the measured one; the range from low to high includes it.
By their numbers in this assay, from the lowest: compounds 2, 3, 1 and 4 (each within the scatter of the next).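

In this assay, within the data shown here, the first measured exchange of chloro for methyl on this aromatic carbon gives a 1.4-fold higher number from compound 3 to compound 4 (0.15 log units; within the scatter), and chloro in place of hydrogen there gives a 1.6-fold higher number from compound 2 to compound 4 (0.20 log units; within the scatter), so neither group separates from hydrogen or from the other at this place. Methyl in place of hydrogen on an aromatic carbon, now read with the chloro present, gives a 1.1-fold higher number from compound 1 to compound 4 (0.05 log units; within the scatter). That change reads alike in both settings: the same change on two cores in this assay, a 1.1-fold higher number (0.05 log units; within the scatter) from compound 2 to compound 3 and a 1.1-fold higher number (0.05 log units; within the scatter) from compound 1 to compound 4, 1.0-fold (0.00 log units) apart, within the scatter of two such steps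

Every step among these four compounds lies within the scatter, so they give no sign of what would move growth inhibition on this aromatic carbon. From the compounds shown here alone, whether an amine or a carboxylic acid there would give a step beyond the scatter stays open.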